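Swapping furan-3-yl for thiophen-3-yl on compound 3

The source may report more compounds than this note shows. Statements on the series, on what has been measured and on what is new or still open speak of the compounds shown alone.

- Compound 1 `CN(C)c1ncnc2c1c(-c1ccoc1)cn2[C@@H]1O[C@H](CO)[C@@H](O)[C@H]1O` gives 99200 nM
- Compound 2 `CN(C)c1ncnc2c1c(-c1ccsc1)cn2[C@@H]1O[C@H](CO)[C@@H](O)[C@H]1O` gives > 100000 nM as a limit of the assay, not a number
- Compound 3 `Cc1ncnc2c1c(-c1ccoc1)cn2[C@@H]1O[C@H](CO)[C@@H](O)[C@H]1O` gives 89200 nM

In an ADME assay on BJ cells (Homo sapiens), read by MTT assay, with a stated time of 72 h (on this read-out higher numbers stand for weaker inhibition and lower numbers for stronger inhibition), compound 3 stands within the scatter of compound 1, so the two cannot be told apart. Compound 4 `Cc1ncnc2c1c(-c1ccsc1)cn2[C@@H]1O[C@H](CO)[C@@H](O)[C@H]1O` differs from compound 3 by one swap (thiophen-3-yl in place of furan-3-yl on an aromatic carbon), with thiophen-3-yl in place of furan-3-yl on an aromatic carbon. On these data alone, the same swap has been measured once (a number no lower from compound 1 to compound 2 (the limit leaves the size open)), and its size stays open. The other measured step changes a different group (a 1.1-fold lower number from compound 1 to compound 3 (0.05 log units; within the scatter)) and stays within the scatter. A small step or none beyond the scatter is therefore expected in this assay and, if anything, towards a higher number. The expected step is small (a 1.1-fold higher number from compound 3 to compound 4 (0.04 log units; within the scatter)). Compound 4 is estimated at 98000 nM with a range (60000 nM to 150000 nM).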

Compound 4, half-maximal inhibitory concentration: 96900 nM
Estimate against measurement, compound 4: 1.0-fold (0.00 log units) above; low and high end bracket the measured number.
By their numbers in this assay, from the lowest: compounds 3, 4 and 1 (each within the scatter of the next). At a limit, above all of these: compound 2.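

In this assay, for the compounds shown here, the swap of furan-3-yl for thiophen-3-yl now has a readable size for the first time, a 1.1-fold higher number from compound 3 to compound 4 (0.04 log units; within the scatter). At this aromatic carbon, sulfur in the ring in place of oxygen therefore leaves the number within the scatter on the methyl-bearing core. Methyl in place of dimethylamino with thiophen-3-yl in place gives an at least 1.0-fold lower number from compound 2 to compound 4 (0.01 log units; that floor lies within the scatter), and the limit leaves its true size open.

On these data alone, it remains open whether a phenyl ring or an amine at this carbon would move the number beyond the scatter. The effect of either group on the shared core is also unknown.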